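The source may hold more compounds than are shown below. What is called first, only, known or untested is meant among the compounds shown, and "the series" means these compounds.

The measured compounds in a functional assay on OVCAR-5 cells (Homo sapiens) for inhibition, read by sulforhodamine B assay, with a stated time of 48 h; a higher number here means a weaker inhibitor of growth, a lower number a stronger inhibitor of growth:
compound 1, `COc1ccc(NC(=O)Nc2n[nH]c3ccccc23)cc1`, > 100000 nM
compound 2, `CCCCOc1ccc(NC(=O)n2nc(N)c3ccccc32)cc1`, 20000 nM
compound 3, `Nc1nn(C(=O)Nc2c(F)cccc2F)c2ccccc12`, < 100000 nM

Only one of these three results is a true number. Compound 1 gives only (the limit of > 100000 nM in this assay, at which 1 of the 3 values shown sits), which is a limit of the assay rather than a measured value. Compound 3 likewise gives only (the limit of < 100000 nM in this assay, at which 1 of the 3 values shown sits), again a limit and not a number. Among the compounds with values here, compound 2 is therefore the single compound with a real measurement in this assay, namely 20000 nM, and it is the reference point for what follows.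

Compound 4, `Nc1nn(C(=O)Nc2ccc(Cc3ccccc3)cc2)c2ccccc12`, has not yet been tested. It differs from compound 2 in one place only: benzyl in place of butoxy on an aromatic carbon. The leaving group and the entering group sit on the same aromatic carbon of the shared core, so the rest of the molecule is unchanged.

Within the data shown here, no measured pair in this set shows how such a swap alters growth inhibition, so there is no step to lean on. The expectation is a shift that is small, if present at all, and within the usual scatter of this assay in either direction. Compound 4 is therefore expected to come in near 20000 nM, with a range from 5000 nM to 80000 nM. That estimate corresponds to a step of no change at the digits printed from compound 2 to compound 4 (within the scatter) that stays close to nothing.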

Compound 4, concentration for 50% growth inhibition: 31300 nM
Compound 4: the middle estimate sits 1.6-fold (0.19 log units) below what was measured, within the range that was stated.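

Benzyl in place of butoxy, on an aromatic carbon para to a large group, gives in this assay a 1.6-fold higher number from compound 2 to compound 4 (0.19 log units; within the scatter), the first step in this set that can be read as a comparison of two true numbers. The two groups are built quite differently, butoxy being a chain with no ring and one hydrogen-bond acceptor, and benzyl carrying a six-membered aromatic ring and no hydrogen-bond acceptor, yet the two values cannot be told apart at this position. Nothing measured in this set accounts for that outcome.

The compounds shown leave open how growth inhibition responds when this position carries a group of another kind, such as an amine, a carboxylic acid or a chain longer than butoxy. Within the data shown here, with only one step at this position, no trend across groups can be claimed, and whether this result would hold in any other cell line also remains open.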